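Benzyl-substituted adenosine analogues against K562 proliferation

The source may hold more compounds than are shown below. What is called first, only, known or untested is meant among the compounds shown, and "the series" means these compounds.

Compound 1 `OC[C@H]1O[C@@H](n2cnc3c(NCc4ccc(Cl)c(Cl)c4)ncnc32)[C@H](O)[C@@H]1O`: 10800 nM
Compound 2 `OC[C@H]1O[C@@H](n2cnc3c(NCc4cc(F)cc(F)c4)ncnc32)C(O)C1O`: > 166000 nM
Compound 3 `COc1ccc(CNc2ncnc3c2ncn3C2OC(CO)[C@@H](O)[C@H]2O)c(O)c1`: 80800 nM

Of the compounds shown here, three sharing the core of compound 1 have been tested in a functional assay on K562 cells (Homo sapiens) for antiproliferative activity, with a stated time of 72 h; on this read-out lower numbers stand for stronger inhibition and higher numbers for weaker inhibition. Compound 1 gives 10800 nM, the lowest of the two numbers recorded. Compound 3, the nearest to it, gives 80800 nM, a gap that is beyond the scatter of the assay. For compound 2 the assay reports only a limit, > 166000 nM, and no number. Among the measured compounds shown here, no single-change step connects any two of the measured compounds, so only the bare values can be compared.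

Compound 4 `OC[C@H]1O[C@@H](n2cnc3c(NCc4ccc(C(F)(F)F)cc4)ncnc32)[C@H](O)[C@@H]1O` is not yet measured. It differs from compound 1 in one place: 4-(trifluoromethyl)phenyl in place of 3,4-dichlorophenyl on a saturated chain carbon bound to a nitrogen on an aromatic ring. For the measured compounds named here, both groups are single carbon-only aromatic rings without hydrogen-bond donors or acceptors, and nothing among the measured compounds isolates this exchange. Compound 4 is therefore expected to stay close to compound 1, with a step of a 1.4-fold higher number from compound 1 to compound 4 (0.14 log units; within the scatter) that need not exceed the scatter. The estimated value for compound 4 in this assay is 15000 nM, within a range from 5000 nM to 60000 nM.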

Compound 4, half-maximal inhibitory concentration: > 166000 nM
Compound 4: only a limit was reported (the forecaster's own chance of this, stated with the estimate: 5%); middle value at least 11-fold (1.04 log units) away from the limit.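

In this assay, among the compounds shown here, the exchange of 3,4-dichlorophenyl for 4-(trifluoromethyl)phenyl on a saturated chain carbon bound to a nitrogen on an aromatic ring gives an at least 15-fold higher number from compound 1 to compound 4 (1.18 log units; beyond the scatter), the first single-change step in this set, and it shows that activity at this position depends on which substituted phenyl group is present. Both groups have one six-membered aromatic ring of carbon only and no hydrogen-bond donors or acceptors, so these shared features do not preserve the activity of compound 1. The result for compound 4 is a limit and not a number, and compound 2 reaches the same limit: the limit of > 166000 nM in this assay, at which 2 of the 4 values shown sit.

The step replaces both chlorine atoms and introduces the trifluoromethyl group together, so the compounds shown do not separate these two parts of the exchange. As far as these compounds go, it also remains open whether a phenyl group bearing a methyl or a nitrile would retain measurable activity.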